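Chloro in Place of Ethyl on the Shared Core

A few compounds are considered here, and "the series" means these few. Any claim that something is new, unique, unknown or untested is made for them only; others in the source may bear on it.

Of the compounds shown here, three built on a shared core have been tested in an ADME assay on MT4 cells (Homo sapiens) for cytotoxicity, read by MTT assay; a higher number here means that more compound is tolerated, a lower number that less compound is tolerated. Compound 1, `Cc1ccccc1NC(=S)OCCc1ccccn1`, gives in this assay only a limit of the assay, > 100000 nM, which is the limit of > 100000 nM in this assay, at which 1 of the 3 values shown sits. Compound 2, `Fc1cccc(NC(=S)OCCc2ccccn2)c1`, likewise gives only a limit in this assay, >= 100000 nM, and that is the limit of >= 100000 nM in this assay, at which 1 of the 3 values shown sits. Among the measured compounds shown here, compound 3, `CCc1ccc(NC(=S)OCCc2ccccn2)cc1`, is the one member with a definite figure: in this assay compound 3 gives 44000 nM. So compound 3 stands as the only number that can be placed on a scale, while the other two results are limits rather than numbers.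

Compound 4, `S=C(Nc1ccc(Cl)cc1)OCCc1ccccn1`, differs from compound 3 in a single spot: chloro in place of ethyl on an aromatic carbon. For the measured compounds named here, no pair of measured compounds shows this same exchange, so no measured step tells how large its effect is. Given how small the exchange is, the expected step from compound 3 to compound 4 is a 1.4-fold higher number from compound 3 to compound 4 (0.13 log units; within the scatter), a modest rise that sits close to the usual scatter rather than clearly beyond it. Compound 4 is therefore expected to give about 60000 nM in this assay, with a range from 25000 nM to 150000 nM, and a fair chance that the assay returns only a limit.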

Compound 4, half-maximal cytotoxic concentration: 52000 nM
Compound 4: the middle estimate sits 1.2-fold (0.06 log units) above what was measured; measured number inside the range.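

Putting chloro in place of ethyl on an aromatic carbon, para to a large group, gives a 1.2-fold higher number from compound 3 to compound 4 (0.07 log units; within the scatter) in this assay, so this read-out cannot tell the two compounds apart. Among the compounds shown here, this is the only measured step on the shared core, and it shows that at this position, ethyl, with its 2 carbon heavy atoms, can give way to a single chlorine without any change that stands clear of the scatter, while compound 4 joins compound 3 in giving a definite figure rather than a limit. The data shown offer no measured reason why this exchange moves the number so little.

One exchange at one position says little about how far this tolerance reaches, and an amine, a carboxylic acid or a longer chain such as butyl in the same place could still give a quite different number. From the compounds shown here alone, it also remains open whether chloro in place of ethyl would read the same way at other places on the ring, or on a core carrying a different chain.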